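The compounds below may be only part of what the source reports. "The series", "measured", "known", "first", "only" and "open" are said of these compounds alone.

Three analogues built on a shared core had been measured before compound 4 was examined. Compound 1 `Cn1nc2c(=O)n(CC3(O)CCN(Cc4ccc(-c5ccco5)cc4Cl)CC3)cnc2c1-c1ccc(C(N)=O)cc1` gave 80.8 nM in an assay on isolated protein for inhibition of ubiquitin carboxyl-terminal hydrolase 7 (Homo sapiens), with stated times of 30 min and 2 h; a lower number here means a stronger inhibitor, a higher number a weaker inhibitor. Among the compounds with values here, compound 2 `CN(C)Cc1ccc(-c2c3ncn(CC4(O)CCN(Cc5ccc(-c6ccco6)cc5Cl)CC4)c(=O)c3nn2C)cc1` gave 131 nM in this assay, and the only single-point step among the measured compounds is a 1.6-fold higher number from compound 1 to compound 2 (0.21 log units; within the scatter). Compound 3 `Cn1nc2c(=O)n(CC3(O)CCN(Cc4ccc(-c5ccsc5Cl)cc4Cl)CC3)cnc2c1-c1ccc(CN)cc1` gave 453 nM in this assay, the highest of the three numbers, so that compound 3 is the weakest inhibitor of the set; both compound 1 and compound 2 lie beyond the scatter below it.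

Compound 4 `Cn1nc2c(=O)n(CC3(O)CCN(Cc4ccc(-c5ccco5)cc4Cl)CC3)cnc2c1-c1ccc(CN)cc1` differs from compound 3 in one place: furan-2-yl in place of 2-chlorothiophen-3-yl on an aromatic carbon. Within the data shown here, no measured step bears directly on this exchange. Among the measured compounds shown here, the one step available, from compound 1 to compound 2, concerns a different group on the other aryl ring and stayed within the scatter. For the measured compounds named here, compound 1 and compound 3 differ in two places at once, so their values alone show only that the furan-bearing compound carries the lower number. Compound 4 carries the furan-2-yl group of compound 1 together with the aminomethyl group of compound 3, so its result is expected to move toward the values of compound 1 and compound 2 rather than stay near compound 3. On that basis the step for compound 4 is estimated as a 3.0-fold lower number from compound 3 to compound 4 (0.48 log units; beyond the scatter). Compound 4 is estimated at 150 nM in this assay, between 60 nM and 400 nM.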

Compound 4, half-maximal inhibitory concentration: 18.1 nM
For compound 4 the middle estimate is 8.3-fold (0.92 log units) above the measured one; measured number below the stated range.
By their numbers in this assay, from the lowest: compound 4; then compounds 1 and 2 (each within the scatter of the next); then compound 3.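

In this assay, the exchange at this position, on an aromatic carbon para to a large group and meta to a chloro group, gives a 25-fold lower number from compound 3 to compound 4 (1.40 log units; beyond the scatter), so with the aminomethyl group held fixed, furan-2-yl in place of 2-chlorothiophen-3-yl accounts for a large drop on its own. The group on the other aryl ring also proves able to move the number with furan-2-yl held fixed: the earlier comparison showed only a 1.6-fold higher number from compound 1 to compound 2 (0.21 log units; within the scatter), whereas the primary amine now gives a 7.2-fold lower number from compound 2 to compound 4 (0.86 log units; beyond the scatter), and aminomethyl in place of carbamoyl gives a 4.5-fold lower number from compound 1 to compound 4 (0.65 log units; beyond the scatter). Compound 4 is thus the strongest inhibitor of the four, its steps to all the others lying beyond the scatter.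

Nothing given here accounts for the size of these steps. The compounds shown do not separate the change of ring from the loss of chlorine, which an unchlorinated thiophen-3-yl at this position would address, and they leave open how a methylamino group or a longer aminoethyl chain on the other aryl ring would compare with aminomethyl.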